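The source may hold more compounds than are shown below. What is called first, only, known or untested is meant among the compounds shown, and "the series" means these compounds.

Series notes. Compound 1 `Cn1c(/C=C/C(=O)c2ccccc2O)cc(Br)c1Br` carries a methyl on the aromatic nitrogen of its five-membered ring. In a functional assay on KB403 cells (Homo sapiens) for cytotoxicity, read by MTT assay, with stated times of 6 h and 48 h (a higher number here means a weaker inhibitor, a lower number a stronger inhibitor), compound 1 gives 8320 nM. Compound 2 `O=C(/C=C/c1cc(Br)c(Br)[nH]1)c1ccccc1O` is the same skeleton after (hydrogen in place of methyl on an aromatic nitrogen). For compound 2 the result in this assay is >= 100000 nM, which is a limit of the assay rather than a number. The step of an at least 12-fold higher number from compound 1 to compound 2 (1.07 log units; beyond the scatter) is therefore only bounded from one side, as it runs into (the limit of >= 100000 nM in this assay, at which 1 of the 3 values shown sits).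

Compound 3 `Cn1c(-c2cc(-c3ccc[nH]3)no2)cc(Br)c1Br` is built on another core; the difference between the core of compound 1 and the core of compound 3 is not broken down here. In this assay compound 3 gives 3100 nM, the lower of the two numbers recorded so far, with compound 1 the nearest to it.

Compound 4 `Brc1cc(-c2cc(-c3ccc[nH]3)no2)[nH]c1Br` has not yet been measured. For the measured compounds named here, it differs from compound 3 by hydrogen in place of methyl on an aromatic nitrogen, which is the same change as the one taken from compound 1 to compound 2, at the same place on the ring. Going by the values given here, the single precedent is an at least 12-fold higher number from compound 1 to compound 2 (1.07 log units; beyond the scatter), where the weaker partner reached the limit, so only a lower bound on the size of that loss exists. On that precedent the step from compound 3 to compound 4 is expected to be a 13-fold higher number from compound 3 to compound 4 (1.11 log units; beyond the scatter), with a real chance that only a limit is reported again. For compound 4 the expected value in this assay is 40000 nM, most likely between 10000 nM and 150000 nM.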

Compound 4, half-maximal inhibitory concentration: 4820 nM
The estimate for compound 4 lay 8.3-fold (0.92 log units) above the measured number, and the stated range ends above it.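

On the core of compound 3, hydrogen in place of methyl on the aromatic nitrogen gives a 1.6-fold higher number from compound 3 to compound 4 (0.19 log units; within the scatter) in this assay, so the large step seen on the core of compound 1 does not carry over to this core at the same size. In these two pairs, the size of the step therefore depends on the core that carries the change: the same change on two cores in this assay, an at least 12-fold higher number (1.07 log units; beyond the scatter) from compound 1 to compound 2 and a 1.6-fold higher number (0.19 log units; within the scatter) from compound 3 to compound 4, at least 7.7-fold (0.88 log units) apart, beyond the scatter of two such steps. For the compounds shown here, the notes do not show the true size of the earlier step or which part of the two cores accounts for the gap, as there is only one pair per core and the weaker partner of the earlier pair sits at a limit of the assay: the limit of >= 100000 nM in this assay, at which 1 of the 4 values shown sits.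

The compounds shown leave open whether a longer chain on that aromatic nitrogen, such as ethyl, or a chain ending in an amine or a carboxylic acid, would read like the methyl compounds or the hydrogen compounds on either core. They also leave open what happens when a chloro group or a hydrogen replaces either bromo group, as all four compounds carry both bromo groups.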